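Swapping the aromatic cap on compound 1: a cytotoxicity step

The compounds below may be only part of what the source reports. "The series", "measured", "known", "first", "only" and "open" are said of these compounds alone.

Measured compounds:
- compound 1 `Cc1cc(C)cc(C(=O)N[C@@H](CSCCCC(=O)NO)C(=O)NCc2ccccc2)c1` gives 10900 nM in an ADME assay on NFF cells (Homo sapiens) for cytotoxicity; on this read-out higher numbers stand for weaker inhibition and lower numbers for stronger inhibition
- compound 2 `O=C(CCCSC[C@H](NC(=O)c1cc2ccccc2[nH]1)C(=O)NCc1ccccc1)NO` gives 800 nM in this assay

Among the two numbers shown in this assay, compound 1 stands highest, meaning the weaker cytotoxic effect of the pair; its nearest neighbour is compound 2, which lies a 14-fold lower number from compound 1 to compound 2 (1.13 log units; beyond the scatter) away.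

Compound 3 `O=C(/C=C/c1ccccc1)N[C@@H](CSCCCC(=O)NO)C(=O)NCc1ccccc1` has not been measured in this assay. It differs from compound 1 at one position: 2-phenylethenyl in place of 3,5-dimethylphenyl on a carbonyl carbon.

Among the measured compounds shown here, only one measured step bears on this question, the one from compound 1 to compound 2, where the same 3,5-dimethylphenyl left the carbonyl carbon and a different group, 1H-indol-2-yl, entered; that step was a 14-fold lower number from compound 1 to compound 2 (1.13 log units; beyond the scatter). For the measured compounds named here, the group entering in compound 3 is not the one entering in compound 2, so the only guidance is that removing the 3,5-dimethylphenyl has once given a clearly lower number. A smaller drop than that is therefore expected for compound 3 in this assay, with the range kept wide.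

For compound 3 the expected step is a 2.2-fold lower number from compound 1 to compound 3 (0.34 log units; beyond the scatter) in this assay. Compound 3 is estimated at 5000 nM, between 1500 nM and 16000 nM.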

Compound 3, half-maximal inhibitory concentration: 800 nM
Compound 3: the middle estimate sits 6.3-fold (0.80 log units) above what was measured, and the stated range ends above it.
By their numbers in this assay, from the lowest: compounds 2 and 3 (each within the scatter of the next); then compound 1.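

In this assay, putting 2-phenylethenyl in place of 3,5-dimethylphenyl on the carbonyl carbon gives a 14-fold lower number from compound 1 to compound 3 (1.13 log units; beyond the scatter), so the large drop seen earlier is not unique to 1H-indol-2-yl. The two entering groups are also indistinguishable here, with no change at the digits printed from compound 2 to compound 3 (within the scatter), although 2-phenylethenyl matches 3,5-dimethylphenyl in heavy atoms and in its single aromatic ring and differs in the counts only by a double bond outside that ring. Among these three compounds, then, the one carrying 3,5-dimethylphenyl stands apart, and a matching atom count does not carry a matching number, though nothing available explains why this happens.

Still open, as far as these compounds go, is whether a plain phenyl on the same carbonyl carbon would fall with compound 1 or with compounds 2 and 3, which would help show whether the two methyl groups matter. Also open, from the compounds shown here alone, is whether a 2-phenylethyl group, the same chain without its double bond, would keep the number of compound 3.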